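Two Chalcone Analogues and a Third Methoxy Group

This account rests on a few compounds, and the source may have more. Where it says the series, first, only, none or still open, it means among the compounds named here.

The study concerns chalcone-bearing compounds assessed in a functional assay on DU-145 cells (Homo sapiens) for antiproliferative activity, read by MTT assay, with a stated time of 24 h; on this read-out higher numbers stand for weaker inhibition and lower numbers for stronger inhibition. Compound 1, with the structure `COc1ccc(C(=O)/C=C/c2cc(-c3cc(OC)c(OC)c(OC)c3)n3nc(-c4ccccc4)cc3n2)cc1`, gives 25200 nM in this assay. Compound 2, with the structure `COc1ccc(-c2cc(/C=C/C(=O)c3ccc(Cl)cc3)nc3cc(-c4ccccc4)nn23)cc1OC`, gives 21300 nM in this assay. The two numbers lie within the scatter of each other, so compound 2 and compound 1 are, on the numbers shown, indistinguishable; neither can be called the stronger inhibitor.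

The step of interest leads from compound 2 to compound 3, whose structure is `COc1cc(-c2cc(/C=C/C(=O)c3ccc(Cl)cc3)nc3cc(-c4ccccc4)nn23)cc(OC)c1OC` and which has not yet been measured in this assay. The change is methoxy in place of hydrogen on an aromatic carbon, turning the 3,4-dimethoxyphenyl group into a 3,4,5-trimethoxyphenyl group. Within the data shown here, no measured pair in this set shows what such a change does to the read-out, so nothing here points to a step beyond the scatter in either direction. The account therefore treats the step from compound 2 to compound 3 as expected to be small, with a 1.3-fold lower number from compound 2 to compound 3 (0.12 log units; within the scatter) as the estimate. For compound 3 the expected value in this assay is 16000 nM, with a range from 5000 nM to 45000 nM.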

Compound 3, half-maximal inhibitory concentration: 29300 nM
Beside the measured number, compound 3's estimate is 1.8-fold (0.26 log units) below it; the measured number falls inside the stated range.
By their numbers in this assay, from the lowest: compounds 2, 1 and 3 (each within the scatter of the next).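

In this assay, among these compounds, the change from 3,4-dimethoxyphenyl to 3,4,5-trimethoxyphenyl now has a measured size (a 1.4-fold higher number from compound 2 to compound 3 (0.14 log units; within the scatter)), which the earlier compounds could not give, and it shows that methoxy in place of hydrogen at this position leaves no difference that can be told from the usual scatter on this pair. The second pair, which keeps the 3,4,5-trimethoxyphenyl group and has chloro in place of methoxy on an aromatic carbon (a 1.2-fold higher number from compound 1 to compound 3 (0.07 log units; within the scatter)), likewise stays within the scatter, so neither single change separates the compounds in this read-out. Nothing measured alongside these compounds speaks to why the numbers sit so close together.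

The compounds shown leave open whether a group other than methoxy at this place, such as an amine, a hydroxyl or a carboxylic acid, would give a step beyond the scatter. They also leave open whether fluoro, trifluoromethyl or nitrile in place of the chloro would do so, since one such exchange on one pair says little about the others.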